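Moving a fluorine on a pyrazinone-type amide series

A few compounds are considered here, and "the series" means these few. Any claim that something is new, unique, unknown or untested is made for them only; others in the source may bear on it.

Measured compounds:
compound 1, `COc1cc2c(Oc3ccc(NC(=O)c4nn(-c5cccc(F)c5)c(=O)c5ccccc45)cc3F)ccnc2cc1OCCCN1CCCC1`, 190 nM
compound 2, `COc1cc2c(Oc3ccc(NC(=O)c4nn(-c5ccccc5F)c(=O)c5ccccc45)cc3F)ccnc2cc1OCCCN1CCCC1`, 230 nM
compound 3, `COc1cc2c(Oc3ccc(NC(=O)c4nn(-c5cccc(F)c5)c(=O)c5ccccc45)cc3F)ccnc2cc1OCCCN1CCC(C)CC1`, 190 nM

All three were tested in a functional assay on NCI-H460 cells (Homo sapiens) for cytotoxicity, read by MTT assay, with a stated time of 72 h; on this read-out lower numbers stand for stronger inhibition and higher numbers for weaker inhibition. Compound 1 and compound 2 share one core and differ only in the change (2-fluorophenyl in place of 3-fluorophenyl on an aromatic nitrogen), which made the step of a 1.2-fold higher number from compound 1 to compound 2 (0.08 log units; within the scatter). Compound 3 carries a different core, and the difference between the two cores is 4-methylpiperidin-1-yl in place of pyrrolidin-1-yl on a saturated chain carbon, three bonds along the chain from an oxygen on an aromatic ring, with the step of no change at the digits printed from compound 1 to compound 3 (within the scatter).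

Compound 4, `COc1cc2c(Oc3ccc(NC(=O)c4nn(-c5ccccc5F)c(=O)c5ccccc45)cc3F)ccnc2cc1OCCCN1CCC(C)CC1`, has not yet been measured. It differs from compound 3 by 2-fluorophenyl in place of 3-fluorophenyl on an aromatic nitrogen. The surroundings of the change are described in the same words for both pairs, so this is the same change already seen from compound 1 to compound 2.

Resting on the step from compound 1 to compound 2, a 1.2-fold higher number from compound 1 to compound 2 (0.08 log units; within the scatter), and on the value of compound 3, 190 nM, the step from compound 3 to compound 4 is expected to be a 1.2-fold higher number from compound 3 to compound 4 (0.08 log units; within the scatter). Compound 4 is therefore estimated at 230 nM, most likely between 120 nM and 450 nM.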

Compound 4, half-maximal inhibitory concentration: 200 nM
Estimate against measurement, compound 4: 1.2-fold (0.06 log units) above; low and high end bracket the measured number.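

In this assay, placing 2-fluorophenyl where 3-fluorophenyl stood gives a 1.1-fold higher number from compound 3 to compound 4 (0.02 log units; within the scatter), and this step matches the one seen on the other core: the same change on two cores in this assay, a 1.2-fold higher number (0.08 log units; within the scatter) from compound 1 to compound 2 and a 1.1-fold higher number (0.02 log units; within the scatter) from compound 3 to compound 4, 1.2-fold (0.06 log units) apart, within the scatter of two such steps. Placing 4-methylpiperidin-1-yl where pyrrolidin-1-yl stood gives a 1.2-fold lower number from compound 2 to compound 4 (0.06 log units; within the scatter), and this step also matches its earlier counterpart: the same change on two cores in this assay, no change at the digits printed (within the scatter) from compound 1 to compound 3 and a 1.2-fold lower number (0.06 log units; within the scatter) from compound 2 to compound 4, 1.2-fold (0.06 log units) apart, within the scatter of two such steps. Among the compounds shown here, each swap therefore left the number within the scatter on both cores, but with steps this small, the match shows only that neither swap had a measurable effect here, not that a larger effect would carry from one core to another or that the same would hold beyond these four compounds.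

The compounds shown leave open whether the number would stay level with a phenyl group carrying no fluorine or with a chlorophenyl group on the aromatic nitrogen. They also leave open what a morpholin-4-yl group or a longer chain would do at the other end of the molecule.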